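A few compounds are considered here, and "the series" means these few. Any claim that something is new, unique, unknown or untested is made for them only; others in the source may bear on it.

Compound 1 `CCCCCCCCNc1cnc(C(=O)NCc2ccccc2)cn1` gives >= 20000 nM in an ADME assay on MDCK cells (Canis lupus familiaris) for cytotoxicity, read by microscopy, with a stated time of 6 days (a higher number here means that more compound is tolerated, a lower number that less compound is tolerated), a limit of the assay rather than a number.
Compound 2 `CCCCNc1nccnc1C(=O)NCc1ccccc1` gives > 100000 nM in this assay, again a limit.
Compound 3 `CCCCNc1cncc(C(=O)NCc2ccccc2)n1` gives 100000 nM in this assay.

Compound 3 is the only one of the three for which a number is recorded; the other two entries stop at a limit. At the limit of > 100000 nM in this assay, at which 1 of the 3 values shown sits, compound 2 sits. At the limit of >= 20000 nM in this assay, at which 1 of the 3 values shown sits, compound 1 sits. Within the data shown here, since those entries are limits, no step between any pair of measured compounds can be counted, so nothing here says how a longer chain moves the read-out.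

Compound 4 `CCCCCCCNc1cncc(C(=O)NCc2ccccc2)n1` is the next compound to be tested. It differs from compound 3 by propyl in place of hydrogen on a saturated chain carbon, four bonds along the chain from a nitrogen on an aromatic ring. Among the measured compounds shown here, with no measured step to lean on, compound 4 is expected to tolerate somewhat less compound than compound 3. The step of a 2.0-fold lower number from compound 3 to compound 4 (0.30 log units; within the scatter) is the one that is expected. The estimate for compound 4 in this assay is 50000 nM, with a range from 15000 nM to 150000 nM.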

Compound 4, minimum cytotoxic concentration: 4000 nM
Estimate against measurement, compound 4: 13-fold (1.10 log units) above, and the stated range ends above it.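

In this assay, propyl in place of hydrogen on a saturated chain carbon, four bonds along the chain from a nitrogen on an aromatic ring, gives a 25-fold lower number from compound 3 to compound 4 (1.40 log units; beyond the scatter). Among these compounds, this is the first step that can be read, as every other pair involves a limit, and it shows that this position is not indifferent to the change: the added propyl alone, with the rest of the molecule unchanged, moves the read-out well beyond the scatter. Nothing measured here gives a reason for this step.

One step cannot tell whether the tolerated concentration falls gradually or abruptly as the chain grows. A pentyl or hexyl chain at this place would help settle that, and a chain ending in an amine or a carboxylic acid would show whether the step follows chain length alone.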